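The compounds below may be only part of what the source reports. "The series", "measured", "known", "first", "only" and "open" are said of these compounds alone.

Measured compounds:
- compound 1, `COc1ccc(-c2cc3ccccc3nc2/C=C/C(=O)c2ccc(O)cc2)cc1`: 6710 nM
- compound 2, `COc1ccc(-c2cc3ccccc3nc2/C=C/C(=O)c2cnc(N)nc2C)cc1`: > 10000 nM

In a functional assay on MCF7 cells (Homo sapiens) for antiproliferative activity, read by XTT assay, with a stated time of 72 h (a lower number here means a stronger inhibitor, a higher number a weaker inhibitor), compound 1 gives 6710 nM. For compound 2 only a limit of this assay is recorded, > 10000 nM, so its standing on the numbers is the limit itself, (the limit of > 10000 nM in this assay, at which 1 of the 2 values shown sits). Compound 3, `COc1ccc(-c2cc3ccccc3nc2/C=C/C(=O)c2c[nH]c3ccccc23)cc1`, differs from compound 2 by 1H-indol-3-yl in place of 2-amino-4-methylpyrimidin-5-yl on a carbonyl carbon. Among the measured compounds shown here, the only measured step on the same carbonyl carbon is an at least 1.4-fold higher number from compound 1 to compound 2 (0.17 log units; that floor lies within the scatter), where an all-carbon aromatic ring gave the lower number and the two-heteroatom ring gave the limit. The 1H-indol-3-yl group brings back a carbon-only six-membered ring with a single donor, so the change is expected to move back toward compound 1, a step of an at least 1.8-fold lower number from compound 2 to compound 3 (0.25 log units; that floor lies within the scatter) in this assay, in the direction of a lower number, though it may stay within the scatter. Compound 3 is estimated at 5500 nM, with a range of 1500 nM to 20000 nM.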

Compound 3, half-maximal inhibitory concentration: > 10000 nM
Compound 3 gave a limit, no number; the forecaster's own chance of this, stated with the estimate: 35%; middle value at least 1.8-fold (0.25 log units) from the limit.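

In this assay, 1H-indol-3-yl on this carbonyl carbon gives an at least 1.4-fold higher number from compound 1 to compound 3 (0.17 log units; that floor lies within the scatter), and that floor does not order the two groups. The carbon-rich fused indole thus ends at the same kind of result as the 2-amino-4-methylpyrimidin-5-yl group, so the change of ring type does not yet separate these two groups, and compound 1 alone holds a number at this place. Compound 2 and compound 3 are both recorded only as limits, and the step between them cannot be read: the limit of > 10000 nM in this assay, at which 2 of the 3 values shown sit.

Still open, on these data alone, is how far compound 2 and compound 3 lie from compound 1, since neither limit gives a size. Also open, as far as these compounds go, is whether a plain phenyl or a 4-aminophenyl group on this carbonyl carbon would give a number in this assay.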